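A few compounds are considered here, and "the series" means these few. Any claim that something is new, unique, unknown or untested is made for them only; others in the source may bear on it.

Measured in a functional assay on the whole organism (strain Sprague-Dawley) for inhibition, with Rattus norvegicus as the target, with a stated time of 10 min; a lower number here means that less compound is needed, a higher number that more compound is needed for the effect:
compound 1 `O=C(O)c1cnc(-c2ccccc2O)[nH]c1=O` gives > 5 mg/kg (a limit)
compound 2 `CC(C)Oc1ccccc1-c1ncc(C(=O)O)c(=O)[nH]1` gives 0.8 mg/kg
compound 3 `CC(C)COc1ccccc1-c1ncc(C(=O)O)c(=O)[nH]1` gives 0.5 mg/kg

Compound 3 has one numeric neighbour: a 1.6-fold lower number from compound 2 to compound 3 (0.20 log units; within the scatter) lies within the scatter. The steps that start from the limit of compound 1 are an at least 6.2-fold lower number from compound 1 to compound 2 (0.79 log units; beyond the scatter) and an at least 10-fold lower number from compound 1 to compound 3 (1.00 log units; beyond the scatter) and both are bounded by that limit.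

Compound 4 `CCC(C)Oc1ccccc1-c1ncc(C(=O)O)c(=O)[nH]1` carries sec-butyl in place of isobutyl on an oxygen on an aromatic ring with the same atoms joined differently. The closest measured exchange gives compound 3 with isobutyl at 0.5 mg/kg and compound 2 with isopropyl at 0.8 mg/kg and these lie within the scatter of each other. No step beyond the scatter is therefore expected in this assay here. The estimated change is a 1.2-fold higher number from compound 3 to compound 4 (0.08 log units; within the scatter) and is expected to stay within the scatter. For compound 4 the estimated value is 0.6 mg/kg with an expected range from 0.25 mg/kg to 1.5 mg/kg in this assay.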

Compound 4, dose for 50% inhibition: 0.5 mg/kg
The estimate for compound 4 lay 1.2-fold (0.08 log units) above the measured number, and the stated range covers the measured number.
By their numbers in this assay, from the lowest: compounds 3, 4 and 2 (each within the scatter of the next). At a limit, above all of these: compound 1.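

Moving from isobutyl to sec-butyl on this oxygen, the same atoms joined differently, gives no change at the digits printed from compound 3 to compound 4 (within the scatter), and the further methyl on the chain gives a 1.6-fold lower number from compound 2 to compound 4 (0.20 log units; within the scatter), so in this assay neither change of branching shifts the number beyond the scatter. Sec-butyl in place of hydrogen gives an at least 10-fold lower number from compound 1 to compound 4 (1.00 log units; beyond the scatter), a third alkyl group with a step beyond the scatter, bounded by a limit. Compound 1 stands at a limit: the limit of > 5 mg/kg in this assay, at which 1 of the 4 values shown sits.

Still open, on these data alone, is whether a longer chain, or a chain ending in an amine, on this oxygen stays within the scatter of compound 3.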